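What One Fluoro Might Change in Compound 1

The source may report more compounds than this note shows. Statements on the series, on what has been measured and on what is new or still open speak of the compounds shown alone.

For the measured compounds named here, in an ADME assay on L6 cells (Rattus norvegicus) for cytotoxicity, read by resazurin assay, with a stated time of 72 h (on this read-out higher numbers stand for weaker inhibition and lower numbers for stronger inhibition), compound 1 (`CC(C)Oc1ccc(C(O)(c2ccc(Cl)cc2)c2cccnc2)cc1`) gives 56600 nM as the only true number so far. In this assay compound 2 (`N#Cc1ccc(C(O)(c2ccc(Cl)cc2)c2cccnc2)cc1`) stands at > 100000 nM which is a limit and not a number. Going by the values given here, the one measured step (an at least 1.7-fold higher number from compound 1 to compound 2 (0.24 log units; that floor lies within the scatter)) replaces the isopropoxy group itself, and its floor lies within the scatter. It therefore says little about compound 3 (`CC(C)Oc1ccc(C(O)(c2ccc(Cl)cc2)c2cccnc2)c(F)c1`), which carries fluoro in place of hydrogen on an aromatic carbon as fluoro in place of hydrogen on an aromatic carbon, ortho to a large group. No step beyond the scatter is expected in this assay and the expected change (a 1.1-fold lower number from compound 1 to compound 3 (0.05 log units; within the scatter)) is small. Compound 3 is estimated at 50000 nM with 22000 nM to 100000 nM as the expected range.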

Compound 3, half-maximal inhibitory concentration: 58200 nM
Estimate against measurement, compound 3: 1.2-fold (0.07 log units) below, and the stated range covers the measured number.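

Fluoro in place of hydrogen gives a 1.0-fold higher number from compound 1 to compound 3 (0.01 log units; within the scatter) in this assay. For the compounds shown here, this is the first reading at this place on the ring, ortho to a large group, whereas the step to compound 2 concerned the isopropoxy group itself. Here, a single fluorine leaves compound 3 within the scatter of compound 1.

From the compounds shown here alone, whether an amine or a carboxylic acid on this same aromatic carbon would do the same stays open. Such a compound could also end at a limit rather than a number: the limit of > 100000 nM in this assay, at which 1 of the 3 values shown sits.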